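The source may report more compounds than this note shows. Statements on the series, on what has been measured and on what is new or still open speak of the compounds shown alone.

Measured compounds:
- compound 1 `CCCOc1ccc(C(=O)Nc2cccc(C)n2)cc1` gives 11100 nM in an in vitro assay on HEK-tsA201 cells for antagonist activity at Neuronal acetylcholine receptor; alpha3/beta4 (Homo sapiens), read by fluorescence and calcium flux; a lower number here means a stronger inhibitor, a higher number a weaker inhibitor
- compound 2 `CCCCNc1cccc(NC(=O)c2ccc(OCCC)cc2)n1` gives 77800 nM in this assay

Compound 2 stands at the higher of the two numbers: its nearest neighbour is compound 1, and the step of a 7.0-fold higher number from compound 1 to compound 2 (0.85 log units; beyond the scatter) places compound 2 beyond the scatter as the weaker inhibitor of the pair.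

Compound 3 `CCCCCCNc1cccc(NC(=O)c2ccc(OCCC)cc2)n1` differs from compound 2 by ethyl in place of hydrogen on a saturated chain carbon, four bonds along the chain from a nitrogen on an aromatic ring. Going by the values given here, no measured step tests this kind of change; the single step available, a 7.0-fold higher number from compound 1 to compound 2 (0.85 log units; beyond the scatter), concerns the arrival of the butylamino group as a whole, not the length of its chain, so it bears only loosely on compound 3. With nothing to point either way, the expected step of a 1.2-fold higher number from compound 2 to compound 3 (0.06 log units; within the scatter) is one within the scatter, and compound 3 is estimated at 90000 nM, within the range 30000 nM to 270000 nM.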

Compound 3, half-maximal inhibitory concentration: > 100000 nM
Compound 3 gave a limit, no number; the forecaster's own chance of this, stated with the estimate: 30%; middle value at least 1.1-fold (0.04 log units) away from the limit.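

In this assay compound 3 gives a limit and not a number, the only such reading among the compounds shown: the limit of > 100000 nM in this assay, at which 1 of the 3 values shown sits. Ethyl in place of hydrogen on this saturated chain carbon amounts to an at least 1.2-fold higher number from compound 2 to compound 3 (0.10 log units; that floor lies within the scatter), so it cannot be told whether the hexylamino chain differs from the butylamino chain beyond the scatter. Set against methyl on the aromatic carbon, hexylamino gives an at least 9.0-fold higher number from compound 1 to compound 3 (0.95 log units; beyond the scatter), so this longer chain, like butylamino in compound 2, goes with a weaker inhibitor than compound 1.

Going by these compounds alone, how far compound 3 really lies from compound 2 stays open, since a limit gives no size for that step. Also open, from the compounds shown here alone, is whether a shorter chain such as ethylamino, or an amine or a carboxylic acid at the end of the chain, would read differently on this core.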